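Compound 3: hydroxy in place of acetamido

A few compounds are considered here, and "the series" means these few. Any claim that something is new, unique, unknown or untested is made for them only; others in the source may bear on it.

In a functional assay on HL-60 cells (Homo sapiens) for inhibition, read by MTT assay, with a stated time of 72 h (on this read-out higher numbers stand for weaker inhibition and lower numbers for stronger inhibition), compound 1 `CC(=O)Nc1cccc(-c2nc(C)oc2C(=O)N2CCN(c3cccc(Cl)c3)CC2)c1` gives 208 nM and compound 2 `Cc1ccc(C)c(N2CCN(C(=O)c3oc(C)nc3-c3ccccc3F)CC2)c1` gives 319 nM as its value, two numbers that lie within the scatter of each other. Among the measured compounds shown here, compound 1 therefore stands level with compound 2 on the numbers so far, and neither can be placed ahead of the other. For the measured compounds named here, no two measured compounds differ in one place only, so the series offers no measured step to lean on.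

Compound 3 `Cc1nc(-c2cccc(O)c2)c(C(=O)N2CCN(c3cccc(Cl)c3)CC2)o1` is compound 1 with hydroxy in place of acetamido on an aromatic carbon, meta to a large group, so that 3-acetamidophenyl becomes 3-hydroxyphenyl (hydroxy in place of acetamido on an aromatic carbon) while the rest of the structure stays the same. The data give no direction for this change, so no shift beyond the scatter is expected in this assay for now. The expected step is a 1.3-fold higher number from compound 1 to compound 3 (0.13 log units; within the scatter) and it is expected to stay within the scatter. Going by the values given here, the range is kept wide, as no measured compound yet shows this change. For compound 3 the estimated value is 280 nM with an expected range of 90 nM to 850 nM in this read-out.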

Compound 3, half-maximal inhibitory concentration: 105 nM
Estimate against measurement, compound 3: 2.7-fold (0.43 log units) above; the measured number falls inside the stated range.
By their numbers in this assay, from the lowest: compounds 3, 1 and 2 (each within the scatter of the next, the first and the last beyond it).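

In this assay, among the compounds shown here, the first single-place step reads a 2.0-fold lower number from compound 1 to compound 3 (0.30 log units; within the scatter), which is within the scatter, so hydroxy in place of acetamido on this aromatic carbon cannot be told apart from no shift. This position thus keeps the number in the range of compound 1 when acetamido gives way to the single oxygen of hydroxy, with the counts of one hydrogen-bond donor and one hydrogen-bond acceptor unchanged, and the carbonyl and methyl of acetamido are not needed to hold the value in this pair. Nothing available accounts for the result.

Open, going by these compounds, is how a methoxy group, an amino group or a carboxylic acid on the same carbon would read, which would show whether the hydrogen-bond donor count matters here or whether the position accepts a wider range of groups. Also open, on these data alone, is whether the change reads the same way on any compound other than compound 1, as this step rests on one pair alone.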